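Methylamino for methoxy on compound 3

The source may hold more compounds than are shown below. What is called first, only, known or untested is meant among the compounds shown, and "the series" means these compounds.

Compound 1 `CCOC(=O)c1cccc(-c2n[nH]c3ccccc23)c1` (5650 nM)
Compound 2 `CCOC(=O)c1ccc(-c2nn(Cc3cccc(F)c3)c3ccccc23)cc1` (270 nM)
Compound 3 `COC(=O)c1ccc(-c2nn(Cc3ccccc3)c3ccccc23)cc1` (560 nM)

All three values come from a functional assay on cells (Platelet, Homo sapiens) for inhibition; a lower number here means a stronger inhibitor, a higher number a weaker inhibitor. Compound 3 holds the middle place among them, with compound 2 lower and compound 1 higher, and both gaps lie beyond the scatter.

Compound 4 `CNC(=O)c1ccc(-c2nn(Cc3ccccc3)c3ccccc23)cc1` differs from compound 3 in one place, with methylamino in place of methoxy on a carbonyl carbon. Among the measured compounds shown here, no measured compound carries methylamino there, and no measured pair shows this change, so the data give no direct size for the step in this assay. The measured values do span a wide range, from compound 2 (270 nM) to compound 1 (5650 nM), so a sizeable step would not fall outside what this small set has shown. A weaker compound is the tentative expectation, with a higher number beyond the scatter. The estimated change is a 3.2-fold higher number from compound 3 to compound 4 (0.51 log units; beyond the scatter), though this remains uncertain. Compound 4 is expected at 1800 nM (estimated range 450 nM to 8000 nM).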

Compound 4, half-maximal inhibitory concentration: > 10000 nM
Compound 4 was reported as a limit; the forecaster's own chance of this, stated with the estimate: 15%; at least 5.5-fold (0.74 log units) between middle value and limit.
By their numbers in this assay, from the lowest: compound 2; then compound 3; then compound 1. At a limit, above all of these: compound 4.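

In this assay, among the compounds shown here, methylamino in place of methoxy on a carbonyl carbon gives an at least 17-fold higher number from compound 3 to compound 4 (1.25 log units; beyond the scatter), the only step in this set that isolates a change at this position. The value of compound 4, > 10000 nM, is a limit and not a number, so the step gives only a minimum size: the limit of > 10000 nM in this assay, at which 1 of the 4 values shown sits. The position is therefore sensitive: an exchange of two heavy atoms for two, which brings in a hydrogen-bond donor, moves the number by this much, although the data do not identify what drives the shift.

From the compounds shown here alone, it remains open whether the amide hydrogen matters or the amide as a whole, and a dimethylamino group on the same carbonyl carbon would separate the two. A carboxylic acid or a propoxy group there would show how far this position extends beyond the methyl ester of compound 3.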